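Benzyloxy Replaced by 4-Chlorophenyl on an Inactive Scaffold

A few compounds are considered here, and "the series" means these few. Any claim that something is new, unique, unknown or untested is made for them only; others in the source may bear on it.

Compound 1 `C=C[C@@](C)(/C=C/c1ccc(OCc2ccccc2)cc1)CCC=C(C)C` was examined in a functional assay on NALM-6 cells (Homo sapiens) for cytotoxicity, with a stated time of 72 h; a lower number here means that less compound is needed, a higher number that more compound is needed for the effect. In this assay compound 1 gives > 43400 nM, which is a limit of the assay and not a number (the limit of > 43400 nM in this assay, at which 1 of the 2 values shown sits). Compound 2 `C=C[C@@](C)(/C=C/c1ccc(O)c(/C=C(\C)C(=O)OCC)c1)CCC=C(C)C` was examined in the same way. In this assay compound 2 gives > 7500 nM, again only a limit (the limit of > 7500 nM in this assay, at which 1 of the 2 values shown sits). Compound 1 therefore stands at a limit, with no measured number of its own to compare against. Compound 3 `C=C[C@@](C)(/C=C/c1ccc(-c2ccc(Cl)cc2)cc1)CCC=C(C)C` differs from compound 1 by 4-chlorophenyl in place of benzyloxy on an aromatic carbon. Among the measured compounds shown here, no step between measured compounds is available, so nothing measured says how this change moves the read-out, and with both measured compounds at limits the step from compound 1 to compound 3 is expected to be none beyond the scatter, most likely ending at a limit again. Compound 3 is estimated at 40000 nM, within a range from 10000 nM to 100000 nM, so that an at least 1.0-fold lower number from compound 1 to compound 3 (0.03 log units; that floor lies within the scatter) is the expected change.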

Compound 3, half-maximal effective concentration: > 43400 nM
Compound 3 ended at the assay's limit (the forecaster's own chance of this, stated with the estimate: 75%); at least 1.0-fold (0.03 log units) between middle value and limit.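

In this assay compound 1 and compound 3 both stand at a limit of the assay, and no step can be read between them. The compounds shown leave open whether 4-chlorophenyl in place of benzyloxy moves the read-out at all.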